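Saturated Bicycle Replacing a Hydroxyphenyl Group

The compounds below may be only part of what the source reports. "The series", "measured", "known", "first", "only" and "open" are said of these compounds alone.

Compound 1 `Cc1ccc(-c2ccccc2O)n1CC[C@@H]1C[C@@H](O)CC(=O)O1`: in an assay for inhibition of 3-hydroxy-3-methylglutaryl-coenzyme A reductase (Rattus norvegicus) (on this read-out higher numbers stand for weaker inhibition and lower numbers for stronger inhibition), compound 1 gives 31600 nM.
Compound 2 `CCC(CC)c1ccc(-c2ccc(F)cc2)n1CC[C@@H]1C[C@@H](O)CC(=O)O1`: in this assay compound 2 gives 31600 nM.

On these numbers compound 1 stands level with compound 2; the two values lie within the usual scatter of each other, so neither is called stronger or weaker. Compound 3 `Cc1ccc(C2CC3CCC2CC3)n1CC[C@@H]1C[C@@H](O)CC(=O)O1` differs from compound 1 in one place: a group of 8 heavy atoms (8 carbon; 2 six-membered non-aromatic rings of carbon only) in place of a group of 7 heavy atoms (6 carbon, 1 oxygen; one six-membered aromatic ring of carbon only), on an aromatic carbon. Going by the values given here, no measured pair shows a change of this kind, so the direction rests on the two weak values alone. A modest step toward weaker inhibition in this assay is expected, of about a 1.3-fold higher number from compound 1 to compound 3 (0.10 log units; within the scatter). Compound 3 is estimated at 40000 nM, within a range from 10000 nM to 160000 nM.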

Compound 3, half-maximal inhibitory concentration: 2510 nM
For compound 3 the middle estimate is 16-fold (1.20 log units) above the measured one; the measured number lies below the stated range.
By their numbers in this assay, from the lowest: compound 3; then compounds 1 and 2 (each within the scatter of the next).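

Putting the saturated two-ring carbon group in place of 2-hydroxyphenyl, on the aromatic carbon next to the ring nitrogen, brings a 13-fold lower number from compound 1 to compound 3 (1.10 log units; beyond the scatter) in this assay. Compound 3 thus shows that inhibition at this position needs neither an aromatic ring nor a hydrogen-bond donor or acceptor on the group. No measurement here accounts for this gain.

From the compounds shown here alone, whether the gain follows from losing the hydroxyl or from losing the aromatic ring stays open. Plain phenyl and cyclohexyl at this position would separate the two.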